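Adding a piperidinylpropyl chain to compound 3

The compounds below may be only part of what the source reports. "The series", "measured", "known", "first", "only" and "open" are said of these compounds alone.

Measured in a functional assay on SMMC-7721 cells (Homo sapiens) for antiproliferative activity, read by MTT assay, with a stated time of 48 h; on this read-out lower numbers stand for stronger inhibition and higher numbers for weaker inhibition:
- Compound 1 `Cn1cc(C2=C(c3nn(CCCN4CCCCC4)c4ncccc34)C(=O)N(c3ccccc3)C2=O)c2ccccc21`: 3050 nM
- Compound 2 `CN1CCN(CCCn2nc(C3=C(c4cn(C)c5ccccc45)C(=O)NC3=O)c3cccnc32)CC1`: > 100000 nM (a limit, not a number)
- Compound 3 `Cn1cc(C2=C(c3n[nH]c4ncccc34)C(=O)NC2=O)c2ccccc21`: > 100000 nM (a limit, not a number)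

Compound 3 has no number of its own. Its > 100000 nM is a limit of the assay. It shares that position with compound 2, as the limit of > 100000 nM in this assay, at which 2 of the 3 values shown sit, records.

Compound 4 `Cn1cc(C2=C(c3nn(CCCN4CCCCC4)c4ncccc34)C(=O)NC2=O)c2ccccc21` is compound 3 with one change: 3-(piperidin-1-yl)propyl in place of hydrogen on an aromatic nitrogen. In words, a 3-(piperidin-1-yl)propyl group takes the place of hydrogen on an aromatic nitrogen.

Within the data shown here, the one measured step at this nitrogen is a step that the two limits leave unreadable from compound 2 to compound 3, so it offers no size to carry over. Compound 1 carries the same 3-(piperidin-1-yl)propyl group and gives 3050 nM, but its core also differs from that of compound 4. Compound 2 shows that a chain on this nitrogen does not guarantee a number in this assay.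

Only a cautious move towards stronger inhibition is therefore expected, and another limit remains quite possible. The expected change is an at least 4.0-fold lower number from compound 3 to compound 4 (0.60 log units; beyond the scatter). Compound 4 is estimated at 25000 nM, with an expected range from 4000 nM to 100000 nM.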

Compound 4, half-maximal inhibitory concentration: 7670 nM
Compound 4: the middle estimate sits 3.3-fold (0.51 log units) above what was measured; the range from low to high includes it.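

In this assay, 3-(piperidin-1-yl)propyl in place of hydrogen on this aromatic nitrogen gives an at least 13-fold lower number from compound 3 to compound 4 (1.11 log units; beyond the scatter), and piperidin-1-yl in place of 4-methylpiperazin-1-yl on the chain gives an at least 13-fold lower number from compound 2 to compound 4 (1.11 log units; beyond the scatter), so in these compounds the amine at the end of the chain matters, not just the presence of a chain. On these data alone, compound 2 and compound 3 each sit at a limit rather than a number, so the true sizes of these two steps stay unknown: the limit of > 100000 nM in this assay, at which 2 of the 4 values shown sit. Hydrogen in place of phenyl on the amide-type nitrogen gives a 2.5-fold higher number from compound 1 to compound 4 (0.40 log units; beyond the scatter), so this chain yields a readable number with or without that phenyl.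

As far as these compounds go, how a shorter or longer chain would behave on this nitrogen remains open. So does the outcome with another amine at the chain's end, such as morpholine or dimethylamine.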